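The source may hold more compounds than are shown below. What is called first, only, known or untested is meant among the compounds shown, and "the series" means these compounds.

Three compounds share one core and differ mainly in what sits on the amide-type nitrogen. Compound 1 `CNC(=O)/C=C1\CCc2c(C)cc(F)cc21` carries a methyl there, and in a functional assay on the whole organism with Rattus norvegicus as the target, with a stated time of 3 h, at a dose of 20 mg/kg by the oral route (on this read-out lower numbers stand for less inhibition and higher numbers for more inhibition at the one dose given (going by the name of the read-out)), compound 1 gives 40%. Compound 3 `CNC(=O)/C=C1\CCc2cc(Cl)cc(Cl)c21` keeps the methyl but carries two chlorines on the core, and compound 3 gives 34%. Compound 2 `Cc1cc(F)cc2c1CC/C2=C\C(=O)NC1CC1` carries a cyclopropyl on that nitrogen, and compound 2 gives 7%, the lowest of the three numbers, with compound 3 standing closest to it and compound 1 furthest. Among the measured compounds shown here, the one step that changes a single place is a number 33 percentage points lower from compound 1 to compound 2 (beyond the scatter), which shows that cyclopropyl in place of methyl cut inhibition well beyond the scatter.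

Compound 4 `Cc1cc(F)cc2c1CC/C2=C\C(N)=O` has not yet been measured. It differs from compound 2 by hydrogen in place of cyclopropyl on an amide-type nitrogen. For the measured compounds named here, no measured pair shows what removing the group altogether does; the only bearing step, a number 33 percentage points lower from compound 1 to compound 2 (beyond the scatter), ran downward when the group grew, so the reverse change is expected to move inhibition upward, though by an uncertain amount. The expected step is a number 23 percentage points higher from compound 2 to compound 4 (beyond the scatter). Compound 4 is therefore estimated at 30%, between 5% and 60%.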

Compound 4, a percentage reported as inhibition, in the whole organism at one dose (the size of the read-out at that dose, not a potency): 24%
The estimate for compound 4 lay 6 percentage points above the measured number, within the range that was stated.
By their numbers in this assay, from the lowest: compound 2; then compounds 4, 3 and 1 (each within the scatter of the next, the first and the last beyond it).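

In this assay hydrogen in place of cyclopropyl on the amide-type nitrogen gives a number 17 percentage points higher from compound 2 to compound 4 (beyond the scatter), so the low number of compound 2 goes with the cyclopropyl itself and not with the shared core. Hydrogen in place of methyl gives a number 16 percentage points lower from compound 1 to compound 4 (beyond the scatter) and thus shows for the first time that the methyl is better than no group at all on this nitrogen. With the core held constant, the three groups run from cyclopropyl at the bottom, through hydrogen, to methyl at the top, so stripping the nitrogen bare does not simply raise the number.

Nothing given here explains this order. From the compounds shown here alone, it also remains open where an ethyl group or a longer carbon chain on the same nitrogen would fall in that order.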